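This account rests on a few compounds, and the source may have more. Where it says the series, first, only, none or still open, it means among the compounds named here.

Compound 3 `COc1ccccc1-c1nnc(-c2ccc(C(=O)N/N=C/c3ccccc3F)cc2)o1` gives the highest of the three numbers in an ADME assay on THP-1 cells (Homo sapiens) for cytotoxicity (a higher number here means a weaker inhibitor, a lower number a stronger inhibitor), namely 313000 nM. Its nearest neighbour is compound 2 `COc1ccc(O)c(/C=N/NC(=O)c2ccc(-c3nnc(-c4ccccc4OC)o3)cc2)c1`, which in this assay gives 303000 nM; the step of a 1.0-fold higher number from compound 2 to compound 3 (0.01 log units; within the scatter) lies within the scatter. Compound 1 `COc1ccccc1-c1nnc(-c2ccc(C(=O)N/N=C/c3c(O)cc(O)cc3O)cc2)o1` stands well apart from both: in this assay compound 1 gives 12400 nM, and the steps of a 24-fold higher number from compound 1 to compound 2 (1.39 log units; beyond the scatter) and a 25-fold higher number from compound 1 to compound 3 (1.40 log units; beyond the scatter) are large.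

Compound 4 `COc1ccccc1-c1nnc(-c2ccc(C(=O)N/N=C/c3ccccc3O)cc2)o1` differs from compound 3 by hydroxy in place of fluoro on an aromatic carbon. Going by the values given here, the step that bears most directly on this is the one from compound 2 to compound 3, where a 2-hydroxy-5-methoxyphenyl gave way to a 2-fluorophenyl and the number in this assay hardly moved. Only the 2,4,6-trihydroxyphenyl of compound 1 produced a large change, and compound 4 carries a single hydroxy rather than three. He therefore expects no step beyond the scatter in this assay from compound 3 to compound 4, a near-flat a 1.3-fold lower number from compound 3 to compound 4 (0.10 log units; within the scatter), with at most a slight tilt towards a lower number because of a 25-fold higher number from compound 1 to compound 3 (1.40 log units; beyond the scatter). His estimate for compound 4 in this assay is 250000 nM, expected to lie between 80000 nM and 650000 nM.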

Compound 4, half-maximal inhibitory concentration: 207000 nM
Compound 4: middle estimate off by 1.2-fold (0.08 log units), on the high side; low and high end bracket the measured number.
By their numbers in this assay, from the lowest: compound 1; then compounds 4, 2 and 3 (each within the scatter of the next).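

In this assay, going by these compounds alone, hydroxy in place of fluoro on this aromatic carbon, ortho to a large group, gives a 1.5-fold lower number from compound 3 to compound 4 (0.18 log units; within the scatter) and so adds one hydrogen-bond donor and one hydrogen-bond acceptor here with no step that can be read beyond the scatter. The methoxy of the 2-hydroxy-5-methoxyphenyl likewise makes no readable difference, with hydrogen in its place giving a 1.5-fold lower number from compound 2 to compound 4 (0.17 log units; within the scatter), which sets the 2-hydroxyphenyl, the 2-fluorophenyl and the 2-hydroxy-5-methoxyphenyl together within the scatter of one another. The same 2-hydroxyphenyl still stands far from the 2,4,6-trihydroxyphenyl, at a 17-fold higher number from compound 1 to compound 4 (1.22 log units; beyond the scatter), so a hydroxy at this place alone does not carry the large step, which among these compounds belongs to the 2,4,6-trihydroxyphenyl of compound 1 as a whole.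

The compounds shown leave open which of the further hydroxy groups of compound 1 matter, and whether an amine or a carboxylic acid on this aromatic carbon would stay within the scatter as hydroxy and fluoro do. No measured evidence is at hand to explain any of these steps.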